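This account rests on a few compounds, and the source may have more. Where it says the series, first, only, none or still open, it means among the compounds named here.

Measured so far:
- compound 1 `C=CCOn1c(C=C)nc2ccc(C)cc21`: 20 uM
- compound 2 `CC(C)=CCOn1c(C=C(C)C)nc2c(C)cccc21`: 50 uM
- compound 3 `CC(C)=CCOn1c(C=C(C)C)nc2ccc(C)cc21`: 50 uM

In a functional assay on C8166 cells (Homo sapiens) for cytotoxicity (on this read-out higher numbers stand for lower toxicity in this test and lower numbers for higher toxicity in this test), compound 1 has the lowest number of the three, and the gaps to compound 2 and compound 3 both lie beyond the scatter. Compound 4 `C=CCOn1c(C=C)nc2ccc(OC)cc21` keeps the core of compound 1 and carries one change: methoxy in place of methyl on an aromatic carbon. Among the measured compounds shown here, no measured pair isolates methoxy in place of methyl, so the data give no direct guide to this step. The estimate therefore rests on compound 1 at 20 uM, and no step beyond the scatter is expected, with a slightly higher number as the expected direction. The expected change is a 1.1-fold higher number from compound 1 to compound 4 (0.04 log units; within the scatter). For compound 4 the estimated value is 22 uM, with an expected range of 9 uM to 55 uM.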

Compound 4, half-maximal toxic concentration: 80 uM
The estimate for compound 4 lay 3.6-fold (0.56 log units) below the measured number; measured number above the stated range.
By their numbers in this assay, from the lowest: compound 1; then compounds 2, 3 and 4 (each within the scatter of the next).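

In this assay, among the compounds shown here, methoxy in place of methyl on the aromatic carbon gives a 4.0-fold higher number from compound 1 to compound 4 (0.60 log units; beyond the scatter) and provides the first single-place comparison. This position therefore affects the read-out, and this change moves it towards lower toxicity in this test, with the rest of compound 1 unchanged. Nothing available accounts for the size of this step. As far as these compounds go, whether the oxygen itself matters remains open: a hydroxy group, an amine or an ethoxy group on the same carbon would test this. From the compounds shown here alone, whether methoxy gives a similar step on the core of compound 3 also remains open.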